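Swapping dimethylamino for hydroxy at the chain end of compound 3

A few compounds are considered here, and "the series" means these few. Any claim that something is new, unique, unknown or untested is made for them only; others in the source may bear on it.

In a functional assay on LNCaP cells (Homo sapiens) for antiproliferative activity (a higher number here means a weaker inhibitor, a lower number a stronger inhibitor), compound 1 `CNC(=O)C[C@@H]1C[C@@H](c2ccc(Cl)c(Cl)c2)[C@H](NC(=O)c2cc(-c3c(Cl)cnn3C)c(Cl)o2)CN1` gives 40 nM, compound 2 `Cn1ncc(Cl)c1-c1cc(C(=O)N[C@@H]2CN[C@H](CC(N)=O)C[C@H]2c2ccc(Cl)c(Cl)c2)oc1Cl` gives 160 nM and compound 3 `CN(C)CC[C@@H]1C[C@@H](c2ccc(Cl)c(Cl)c2)[C@H](NC(=O)c2cc(-c3c(Cl)cnn3C)c(Cl)o2)CN1` gives 1930 nM. That last number is the highest of the three, making compound 3 the weakest inhibitor so far.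

The next structure, compound 4 `Cn1ncc(Cl)c1-c1cc(C(=O)N[C@@H]2CN[C@H](CCO)C[C@H]2c2ccc(Cl)c(Cl)c2)oc1Cl`, carries hydroxy in place of dimethylamino on a saturated chain carbon, two bonds along the chain from a saturated ring carbon.

Two measured steps change this same chain end, and both are large: a 48-fold higher number from compound 1 to compound 3 (1.68 log units; beyond the scatter) and a 12-fold higher number from compound 2 to compound 3 (1.08 log units; beyond the scatter). The step of a 4.0-fold higher number from compound 1 to compound 2 (0.60 log units; beyond the scatter) is only modest, so the two amide-ended compounds stand closer to each other than either stands to compound 3. Among the compounds with values here, no measured compound carries hydroxy, so this read-across is indirect. A clear move to a lower number is expected, probably smaller than the step from the methylcarbamoyl compound. The expected change is a 5.5-fold lower number from compound 3 to compound 4 (0.74 log units; beyond the scatter). For compound 4 the estimated value is 350 nM, with an expected range of 90 nM to 1300 nM.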

Compound 4, half-maximal inhibitory concentration: 160 nM
For compound 4 the middle estimate is 2.2-fold (0.34 log units) above the measured one; the range from low to high includes it.
By their numbers in this assay, from the lowest: compound 1; then compounds 2 and 4 (each within the scatter of the next); then compound 3.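

In this assay, the hydroxy group at this chain end gives a 12-fold lower number from compound 3 to compound 4 (1.08 log units; beyond the scatter) in place of dimethylamino, so the high number of compound 3 does not hold for every non-amide chain end. The hydroxymethyl and carbamoyl groups show no change at the digits printed from compound 2 to compound 4 (within the scatter) at this position, so an amide carbonyl is not required to match compound 2, while methylcarbamoyl in compound 1 remains the strongest of the set, with a 4.0-fold higher number from compound 1 to compound 4 (0.60 log units; beyond the scatter) on moving to hydroxymethyl. Nothing measured here explains these differences.

The compounds shown do not separate the loss of dimethylamino from the gain of hydroxy, a question that a primary amine or a methoxy group at the same chain end could address. As far as these compounds go, how a carboxylic acid at this position or a longer chain carrying the hydroxy would read also remains open.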